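Second fluoro on the sulfonyl-bearing ring: clearance notes

The compounds below may be only part of what the source reports. "The series", "measured", "known", "first", "only" and "open" are said of these compounds alone.

Three members of this series have been run through an ADME assay on microsomes from liver (Homo sapiens) for metabolic stability, tested at 2.5 uM; on this read-out higher numbers stand for fast clearance and lower numbers for slow clearance. Compound 1 `O=S(=O)(c1cc(F)cc(F)c1)c1cnc2c(F)cccc2c1-c1ccccc1F` gives 0.09 mL/min, compound 2 `O=S(=O)(c1cccc(F)c1)c1cnc2c(F)cccc2c1-c1ccccc1F` gives 0.21 mL/min, and compound 3 `O=S(=O)(c1ccc(F)cc1)c1cnc2c(F)cccc2c1-c1cccc(Cl)c1` gives 1.21 mL/min. Between compound 2 and compound 1 the only change is fluoro in place of hydrogen on an aromatic carbon, and in this assay that change produced a 2.3-fold lower number from compound 2 to compound 1 (0.37 log units; beyond the scatter). Compound 3 carries the highest number of the three; the difference between its core and that of compound 2 is not broken down here, so only the values themselves are compared.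

Compound 4 `O=S(=O)(c1ccc(F)c(F)c1)c1cnc2c(F)cccc2c1-c1cccc(Cl)c1` has not yet been measured. Relative to compound 3 it shows (fluoro in place of hydrogen on an aromatic carbon). Among the measured compounds shown here, this is the same kind of change as the one from compound 2 to compound 1, but not the same: there the entering fluoro was meta to a fluoro group, here it is ortho to a fluoro group, in both cases meta to a large group.

The expectation for compound 4 in this assay rests on the earlier step, because a 2.3-fold lower number from compound 2 to compound 1 (0.37 log units; beyond the scatter) pointed toward a lower number. Compound 4 is therefore estimated at 0.6 mL/min, with a range from 0.3 mL/min to 1.3 mL/min. The step this estimate implies, a 2.0-fold lower number from compound 3 to compound 4 (0.30 log units; within the scatter), is expected to be of modest size, the wider range reflecting the different placement of the entering fluoro.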

Compound 4, intrinsic clearance in a liver preparation (reported as CLH), per the amount of preparation that the assay uses: 1.13 mL/min
The estimate for compound 4 lay 1.9-fold (0.27 log units) below the measured number, and the stated range covers the measured number.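

In this assay, going from 4-fluorophenyl to 3,4-difluorophenyl gives a 1.1-fold lower number from compound 3 to compound 4 (0.03 log units; within the scatter), so the two values cannot be told apart on this core. Set beside the earlier step, the two readings do not separate from one another: the same change on two cores in this assay, a 2.3-fold lower number (0.37 log units; beyond the scatter) from compound 2 to compound 1 and a 1.1-fold lower number (0.03 log units; within the scatter) from compound 3 to compound 4, 2.2-fold (0.34 log units) apart, within the scatter of two such steps. Among the compounds shown here, this shows no measurable dependence on the core, but it does not show that the change carries over reliably: there is only one pair per core, only the earlier step lies beyond the scatter, and the entering fluoro is placed differently in the two pairs, so core and placement cannot be separated.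

The compounds shown leave open how a fluoro entering at the same place would read on both cores. They also leave open whether a group of another kind on the sulfonyl-bearing ring, such as an amine, a carboxylic acid or a longer chain, would give a step that transfers between these cores.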